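This account rests on a few compounds, and the source may have more. Where it says the series, first, only, none or still open, it means among the compounds named here.

Measured in a functional assay on MCF7 cells (Homo sapiens) for antiproliferative activity, read by MTT assay, with a stated time of 72 h; on this read-out higher numbers stand for weaker inhibition and lower numbers for stronger inhibition:
compound 1 `CCN1CCN(c2cc(C)c3cc(NC(=O)c4ccccc4C)ccc3n2)CC1` gives 10900 nM
compound 2 `CCN1CCN(c2cc(C)c3cc(NC(=O)c4ccccc4F)ccc3n2)CC1` gives 32600 nM

Among the compounds with values here, on these two numbers compound 2 stands highest, and its only neighbour is compound 1, the two being separated by a 3.0-fold higher number from compound 1 to compound 2 (0.48 log units; beyond the scatter). Compound 3 `CCN1CCN(c2cc(C)c3cc(NC(=O)c4cc5ccccc5[nH]4)ccc3n2)CC1` has not yet been measured. It differs from compound 2 in one place: 1H-indol-2-yl in place of 2-fluorophenyl on a carbonyl carbon. Within the data shown here, no measured step matches this exchange; the single step known, a 3.0-fold higher number from compound 1 to compound 2 (0.48 log units; beyond the scatter), concerns a different swap on the carbonyl carbon and shows only that the group there can shift the number by a modest amount. On that basis, with the direction uncertain yet leaning toward a lower number, the expected step in this assay is estimated as a 2.2-fold lower number from compound 2 to compound 3 (0.34 log units; beyond the scatter). Compound 3 is therefore estimated at 15000 nM, within a range from 3000 nM to 60000 nM.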

Compound 3, half-maximal inhibitory concentration: 2950 nM
Compound 3: the middle estimate sits 5.1-fold (0.71 log units) above what was measured; measured number outside the range, below it.
By their numbers in this assay, from the lowest: compound 3; then compound 1; then compound 2.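

In this assay, the group on the carbonyl carbon can shift the number much further than the earlier pair suggested, with an 11-fold lower number from compound 2 to compound 3 (1.04 log units; beyond the scatter) as a large step. The 1H-indol-2-yl group also outperforms the 2-methylphenyl group, with a 3.7-fold lower number from compound 1 to compound 3 (0.57 log units; beyond the scatter) as a modest step, so it gives the strongest inhibition of the three groups shown at this place. Nothing available explains why this exchange lowers the number.

The exchange adds a five-membered aromatic ring and a hydrogen-bond donor together, and the compounds shown cannot separate these two changes. A benzofuran-2-yl group, with oxygen in place of the ring nitrogen and its hydrogen, would keep both rings on the same carbonyl carbon and leave open whether that hydrogen matters.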